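The source may hold more compounds than are shown below. What is called first, only, known or untested is meant among the compounds shown, and "the series" means these compounds.

Measured compounds:
compound 1 `CN1CCN(c2ccc(C3=NNC(c4ccc(N(C)C)cc4)C3)cc2)CC1` — 31.2%
compound 2 `CC(=O)N1N=C(c2ccc(N3CCN(C)CC3)cc2)CC1c1ccc(N(C)C)cc1` — -0.8%
compound 3 `COC(=O)CC(=O)N1N=C(c2ccc(N3CCN(C)CC3)cc2)CC1c1ccc(N(C)C)cc1` — -8.3%

In a functional assay on HCC1806 cells (Homo sapiens) for inhibition, read by sulforhodamine B assay, tested at 10 uM (on this read-out higher numbers stand for more inhibition at the one concentration tested (going by the name of the read-out) and lower numbers for less inhibition), compound 1 stands highest of the three numbers; the steps to the other two are a number 32 percentage points lower from compound 1 to compound 2 (beyond the scatter) and a number 39.5 percentage points lower from compound 1 to compound 3 (beyond the scatter), both large and beyond the scatter. Compound 4 `Cc1ccc(C(=O)N2N=C(c3ccc(N4CCN(C)CC4)cc3)CC2c2ccc(N(C)C)cc2)cc1` differs from compound 1 by (4-methylphenyl)carbonyl in place of hydrogen on an amine nitrogen in a ring. Both measured steps from compound 1 replace the same hydrogen on the ring amine nitrogen with a carbonyl-bearing group, and both wipe out the inhibition; the further step a number 7.5 percentage points lower from compound 2 to compound 3 (within the scatter) lies within the scatter, so what hangs off the carbonyl made no visible difference there. A large drop is therefore expected again, a number 33.2 percentage points lower from compound 1 to compound 4 (beyond the scatter). Compound 4 is estimated at -2%, with a range of -15% to 12%.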

Compound 4, a percentage reported as inhibition, at one concentration (the size of the read-out at that concentration, not a potency): -2.5%
The estimate for compound 4 lay 0.5 percentage points above the measured number, within the range that was stated.
By their numbers in this assay, from the lowest: compounds 3, 4 and 2 (each within the scatter of the next); then compound 1.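

In this assay an aromatic group on the carbonyl gives the same outcome as the smaller acyl groups: there is again a large fall with (4-methylphenyl)carbonyl on the amine nitrogen in the ring, a number 33.7 percentage points lower from compound 1 to compound 4 (beyond the scatter) and the carbonyl substituent makes no difference beyond the scatter, with a number 1.7 percentage points lower from compound 2 to compound 4 (within the scatter) and a number 5.8 percentage points higher from compound 3 to compound 4 (within the scatter) as the two steps. Compounds 2, 3 and 4 thus sit together, apart from compound 1 with its hydrogen at this position. No measured evidence bears on the reason for this result.

Still open, as far as these compounds go, is whether a group without a carbonyl on that nitrogen, such as benzyl or a plain methyl, keeps the inhibition seen with hydrogen. Also open, from the compounds shown here alone, is whether a carbonyl carrying an amine or a carboxylic acid on a longer chain would behave differently.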